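Swapping fluoro for bromo at a measurement limit

The compounds below may be only part of what the source reports. "The series", "measured", "known", "first", "only" and "open" are said of these compounds alone.

In a functional assay on BGC-823 cells (Homo sapiens) for antiproliferative activity, read by MTT assay, with a stated time of 24 h (on this read-out higher numbers stand for weaker inhibition and lower numbers for stronger inhibition), three compounds have been measured so far:

Compound 1 `O=[N+]([O-])c1ccc(CSc2nnc(-c3ccc4c(c3)OCCO4)n2-c2ccccc2)cc1` gives 48600 nM
Compound 2 `Cc1ccccc1CSc1nnc(-c2ccc3c(c2)OCCO3)n1-c1ccccc1` gives > 100000 nM (a limit, not a number)
Compound 3 `Fc1ccc(CSc2nnc(-c3ccc4c(c3)OCCO4)n2-c2ccccc2)cc1` gives > 100000 nM (a limit, not a number)

Compound 3 therefore offers no exact starting number, only its limit of > 100000 nM in this assay. Two of the three results share this position: the limit of > 100000 nM in this assay, at which 2 of the 3 values shown sit.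

Compound 4 `Brc1ccc(CSc2nnc(-c3ccc4c(c3)OCCO4)n2-c2ccccc2)cc1` is compound 3 with a single change, bromo in place of fluoro on an aromatic carbon, para to a large group (bromo in place of fluoro on an aromatic carbon).

Among the measured compounds shown here, no measured step makes this exact swap. The closest one puts fluoro in place of nitro, an at least 2.0-fold higher number from compound 1 to compound 3 (0.31 log units; beyond the scatter), and it is at least modest. Another replaces the whole 4-nitrophenyl group, an at least 2.0-fold higher number from compound 1 to compound 2 (0.31 log units; beyond the scatter), and is also at least modest. The remaining step, a step that the two limits leave unreadable from compound 2 to compound 3, cannot be sized. Neither readable step exchanges one halogen for another, so only a small change is expected, with compound 4 staying close to the limit. The expected size of the change is an at least 1.1-fold lower number from compound 3 to compound 4 (0.04 log units; that floor lies within the scatter). For compound 4 the estimated value is 90000 nM, with an expected range of 40000 nM to 200000 nM.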

Compound 4, half-maximal inhibitory concentration: 33800 nM
The estimate for compound 4 lay 2.7-fold (0.43 log units) above the measured number, and the stated range ends above it.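

Bromo in place of fluoro on this aromatic carbon, para to a large group, gives an at least 2.9-fold lower number from compound 3 to compound 4 (0.47 log units; beyond the scatter) in this assay, and none of the earlier steps exchanged one halogen for another, so this shows that the choice of halogen at this place can change the read-out beyond the scatter. The 4-bromophenyl group also separates from the 2-methylphenyl group, with an at least 2.9-fold lower number from compound 2 to compound 4 (0.47 log units; beyond the scatter), while bromo in place of nitro gives a 1.4-fold lower number from compound 1 to compound 4 (0.16 log units; within the scatter), so compound 1 and compound 4 cannot be told apart and bromo joins nitro on the more active side of this small set. Compound 3 sits at a limit and not at a number, so the true size of its step to compound 4 stays unknown: the limit of > 100000 nM in this assay, at which 2 of the 4 values shown sit.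

A single pair of halogens cannot show whether chloro or iodo at this place would fall with compound 3 or with compound 4, or where a methoxy group or an amine would land. Also open, as far as these compounds go, is whether the 4-bromobenzyl group keeps this level when its chain is made longer.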